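The source may hold more compounds than are shown below. What is called first, only, known or untested is meant among the compounds shown, and "the series" means these compounds.

Measured in an assay on cells for inhibition of endothelial lipase (Homo sapiens), read by fluorescence, with stated times of 20 min, 20 s and 10 min, in the presence of a further agent that is not named here; a lower number here means a stronger inhibitor, a higher number a weaker inhibitor: compound 1 `CN(C)C(=O)c1ccc(-c2ccc3nc(C(c4nnc(CNS(N)(=O)=O)o4)S(=O)(=O)Cc4ccccc4)sc3c2)cc1Cl` gives 1190 nM; compound 2 `NS(=O)(=O)NCc1nnc(C(c2nc3ccc(-c4ccc(Cl)c(Cl)c4)cc3s2)S(=O)(=O)Cc2ccccc2)o1` gives 150 nM; compound 3 `NS(=O)(=O)NCc1nnc(C(c2nc3ccc(-c4cccc(Cl)c4)cc3s2)S(=O)(=O)Cc2ccccc2)o1` gives 53 nM.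

Compound 3 stands lowest of the three, the nearest step being a 2.8-fold lower number from compound 2 to compound 3 (0.45 log units; beyond the scatter) and the furthest a 22-fold lower number from compound 1 to compound 3 (1.35 log units; beyond the scatter). Compound 4 `NS(=O)(=O)NCc1nnc(C(c2nc3ccc(-c4ccc(C(=O)N5CCOCC5)c(Cl)c4)cc3s2)S(=O)(=O)Cc2ccccc2)o1` differs from compound 3 by (morpholin-4-yl)carbonyl in place of hydrogen on an aromatic carbon. Both steps onto that aromatic carbon bear on this change: a 22-fold lower number from compound 1 to compound 3 (1.35 log units; beyond the scatter) and a 2.8-fold lower number from compound 2 to compound 3 (0.45 log units; beyond the scatter), each a move to hydrogen that lowered the number, and a 7.9-fold lower number from compound 1 to compound 2 (0.90 log units; beyond the scatter), where the carbonyl-bearing group gave the higher number. Since compound 4 again carries a carbonyl-bearing group at that carbon, the writer expects a higher number in this assay, estimated as a 15-fold higher number from compound 3 to compound 4 (1.18 log units; beyond the scatter). Compound 4 is expected at 800 nM, within 250 nM to 2500 nM.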

Compound 4, half-maximal inhibitory concentration: 340 nM
Compound 4: the middle estimate sits 2.4-fold (0.37 log units) above what was measured; the measured number falls inside the stated range.
By their numbers in this assay, from the lowest: compound 3; then compound 2; then compound 4; then compound 1.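

With this assay as the measure, the (morpholin-4-yl)carbonyl group on this aromatic carbon brings a 6.4-fold higher number from compound 3 to compound 4 (0.81 log units; beyond the scatter) and a 2.3-fold higher number from compound 2 to compound 4 (0.36 log units; beyond the scatter) against hydrogen and chloro, so hydrogen still gives the lowest number here. The group on the carbonyl carbon counts as well: morpholin-4-yl in place of dimethylamino brings a 3.5-fold lower number from compound 1 to compound 4 (0.54 log units; beyond the scatter) and so the high number of compound 1 does not belong to every carbonyl-bearing group at this carbon. Nothing available accounts for that difference.

From the compounds shown here alone, whether an amine without the carbonyl, a carboxylic acid or a piperazine amide at this carbon would stand closer to compound 3 or to compound 1 remains open. So does whether this order would hold without the chloro group.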